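Allylphenol biaryls: removing the trifluoromethyl group

The source may report more compounds than this note shows. Statements on the series, on what has been measured and on what is new or still open speak of the compounds shown alone.

Measured compounds in a functional assay on HepG2 cells (Homo sapiens) for antiproliferative activity, read by MTT assay, with a stated time of 24 h; on this read-out lower numbers stand for stronger inhibition and higher numbers for weaker inhibition:
- compound 1 `C=CCc1cc(-c2ccc(C(F)(F)F)cc2)ccc1O`, compound 1 gives 60300 nM
- compound 2 `C=CC(C)(C)c1cc(-c2cccc([N+](=O)[O-])c2)ccc1O`, compound 2 gives 56000 nM
- compound 3 `C=CCc1cc(C=O)c(OCC(=O)OCC)c(-c2ccc(OCC(=O)OCC)c(CC=C)c2)c1`, for compound 3 only a limit is recorded, > 85200 nM

Compound 1 holds the higher of the two numbers in this assay. Compound 2 gives the nearest number, and the two lie within the scatter of each other, so no order between them can be stated. The value for compound 3 is a limit of the assay, not a number (the limit of > 85200 nM in this assay, at which 1 of the 3 values shown sits).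

Compound 4 `C=CCc1cc(-c2ccccc2)ccc1O` differs from compound 1 by hydrogen in place of trifluoromethyl on an aromatic carbon.

Among the measured compounds shown here, no measured pair isolates this change, so the expected step rests on compound 1 alone. The number for compound 4 is expected to stay close to that of compound 1, with at most a modest move toward a higher number, so a step of roughly a 1.2-fold higher number from compound 1 to compound 4 (0.09 log units; within the scatter) is expected. Compound 4 is therefore estimated at 75000 nM, within a range of 30000 nM to 160000 nM in this assay, and a limit rather than a number remains a real possibility.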

Compound 4, half-maximal inhibitory concentration: > 100000 nM
Compound 4: no number, only a limit; the forecaster's own chance of this, stated with the estimate: 35%; at least 1.3-fold (0.12 log units) between middle value and limit.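

In this assay, hydrogen in place of trifluoromethyl on an aromatic carbon, para to a large group, gives an at least 1.6-fold higher number from compound 1 to compound 4 (0.21 log units; that floor lies within the scatter). Compound 4 carries a limit of the assay, not a number: the limit of > 100000 nM in this assay, at which 1 of the 4 values shown sits.

Among the compounds shown here, this is the first single-change step, and it shows that compound 1 reads as a number with trifluoromethyl at this position, while the hydrogen analogue gives only a limit. As far as these compounds go, the step has only a floor, so its true size stays unknown and it may or may not exceed the scatter.

For the compounds shown here, compound 2 and compound 3 differ from compound 4 in more than one place and add no step at this position. Open, from the compounds shown here alone, is whether a chlorine, a nitrile or a carboxylic acid at this carbon would give a number, and how it would compare with compound 1.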